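This account rests on a few compounds, and the source may have more. Where it says the series, first, only, none or still open, it means among the compounds named here.

Measured compounds:
- compound 1, `O=C(NCCO)c1cccc(Nc2ncc(F)c(Nc3ccc(F)cc3)n2)c1`: 21400 nM
- compound 2, `O=C(Nc1cc(Cl)cc(Cl)c1)c1cccc(Nc2ncc(F)c(Nc3ccc(F)cc3)n2)c1`: 20700 nM
- compound 3, `O=C(Nc1cccc(Nc2ncc(F)c(Nc3ccc(F)cc3)n2)c1)c1ccncc1`: 4570 nM

In a functional assay on KBVIN cells (Homo sapiens) for antiproliferative activity, read by sulforhodamine B assay, with a stated time of 3 days (on this read-out higher numbers stand for weaker inhibition of growth and lower numbers for stronger inhibition of growth), compound 3 gives the lowest of the three numbers. Its steps to the other two are both beyond the scatter: a 4.7-fold lower number from compound 1 to compound 3 (0.67 log units; beyond the scatter) and a 4.5-fold lower number from compound 2 to compound 3 (0.66 log units; beyond the scatter). Compound 1 and compound 2 are within the scatter of each other, as the step of a 1.0-fold lower number from compound 1 to compound 2 (0.01 log units; within the scatter) shows.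

Compound 4, `CN1CCC(C(=O)Nc2cccc(Nc3ncc(F)c(Nc4ccc(F)cc4)n3)c2)CC1`, keeps the shared core of compound 3 and changes only the group on the carbonyl carbon: 1-methylpiperidin-4-yl in place of pyridin-4-yl on a carbonyl carbon. Going by the values given here, none of the measured steps changes this group while leaving the rest of the molecule in place. The two steps that reach compound 3 replace the whole amide-bearing side chain at once, so they tell how much the amide region can move this assay but not what the piperidine ring does on the carbonyl carbon. The step from compound 1 to compound 2, which changes the group on the amide-type nitrogen, lies within the scatter.

Among the compounds with values here, with no step on this carbonyl carbon to draw on, a change of roughly the size seen between compound 1 and compound 2 is expected, that is none beyond the scatter, with the direction uncertain, so that compound 4 is expected at a 1.1-fold higher number from compound 3 to compound 4 (0.04 log units; within the scatter). Compound 4 is therefore estimated at 5000 nM in this assay, within a range from 1500 nM to 16000 nM.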

Compound 4, concentration for 50% growth inhibition: 11900 nM
Estimate against measurement, compound 4: 2.4-fold (0.38 log units) below; measured number inside the range.
By their numbers in this assay, from the lowest: compound 3; then compounds 4, 2 and 1 (each within the scatter of the next).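

In this assay the group on this carbonyl carbon now has a step of its own: with the rest of the molecule in place, 1-methylpiperidin-4-yl in place of pyridin-4-yl gives a 2.6-fold higher number from compound 3 to compound 4 (0.42 log units; beyond the scatter) and so shows that this one group, and not only a change of the whole side chain, can move the number beyond the scatter. The non-aromatic ring does not keep what the pyridin-4-yl ring gave, since a 1.7-fold lower number from compound 2 to compound 4 (0.24 log units; within the scatter) and a 1.8-fold lower number from compound 1 to compound 4 (0.25 log units; within the scatter) both lie within the scatter, which leaves compound 3 as the only one of the four set apart from the others by printed steps beyond the scatter. Nothing measured on these compounds explains this difference.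

The compounds shown leave open whether the step goes with the loss of the aromatic ring or with the methyl on the ring nitrogen, a question that a phenyl ring, a pyridin-3-yl ring or an unsubstituted piperidin-4-yl on this carbonyl carbon would address. Also open, from the compounds shown here alone, is what an open-chain amine, such as a dimethylaminomethyl group, would do at the same place.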